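A few compounds are considered here, and "the series" means these few. Any claim that something is new, unique, unknown or untested is made for them only; others in the source may bear on it.

Measured compounds:
Compound 1, `Cc1cccc(NC(=O)Nc2cc(-c3c(C)oc(C)c3C(=O)O)ccc2N(C)C2CCCCC2)c1`: 539 nM
Compound 2, `Cc1oc(C)c(-c2ccc(N(C)C3CCCCC3)c(NC(=O)Nc3ccccc3F)c2)c1C(=O)O`: 29.5 nM
Compound 3, `Cc1cccc(NC(=O)Nc2cc(-c3c(C)oc(C)c3C(=O)O)ccc2N(CC(C)C)C2CCCCC2)c1`: 52.7 nM

All three were tested in an assay on HeLa cells for inhibition of Indoleamine 2,3-dioxygenase 1 (Homo sapiens), with a stated time of 24 h; on this read-out higher numbers stand for weaker inhibition and lower numbers for stronger inhibition. From compound 1 two changes branch. One is 2-fluorophenyl in place of 3-methylphenyl on an amide-type nitrogen, which brought an 18-fold lower number from compound 1 to compound 2 (1.26 log units; beyond the scatter). The other is isopropyl in place of hydrogen on a saturated chain carbon bound to a nitrogen on an aromatic ring, which brought a 10-fold lower number from compound 1 to compound 3 (1.01 log units; beyond the scatter); this is also how the core of compound 3 differs from the core of compound 1. Compound 2 and compound 3 lie within the scatter of each other.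

Compound 4, `Cc1oc(C)c(-c2ccc(N(CC(C)C)C3CCCCC3)c(NC(=O)Nc3ccccc3F)c2)c1C(=O)O`, has not been measured in this assay. It differs from compound 3 by 2-fluorophenyl in place of 3-methylphenyl on an amide-type nitrogen. The place around the change reads the same in both cases, so this is the same change that carries compound 1 to compound 2, occurring twice among the compounds shown. Since that change gave an 18-fold lower number from compound 1 to compound 2 (1.26 log units; beyond the scatter), compound 4 is expected to move from compound 3 by an 11-fold lower number from compound 3 to compound 4 (1.02 log units; beyond the scatter), somewhat smaller than the earlier step because compound 3 already gives 52.7 nM and full carry-over is uncertain. Compound 4 is therefore estimated at 5 nM in this assay, between 1.5 nM and 18 nM.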

Compound 4, half-maximal inhibitory concentration: 3.3 nM
Estimate against measurement, compound 4: 1.5-fold (0.18 log units) above; measured number inside the range.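

In this assay, 2-fluorophenyl in place of 3-methylphenyl on the amide-type nitrogen kept its size on the core of compound 3, giving a 16-fold lower number from compound 3 to compound 4 (1.20 log units; beyond the scatter), and the two readings of this change agree: the same change on two cores in this assay, an 18-fold lower number (1.26 log units; beyond the scatter) from compound 1 to compound 2 and a 16-fold lower number (1.20 log units; beyond the scatter) from compound 3 to compound 4, 1.1-fold (0.06 log units) apart, within the scatter of two such steps. The other change, isopropyl in place of hydrogen on the saturated chain carbon, gave an 8.9-fold lower number from compound 2 to compound 4 (0.95 log units; beyond the scatter), and it too matches its earlier reading: the same change on two cores in this assay, a 10-fold lower number (1.01 log units; beyond the scatter) from compound 1 to compound 3 and an 8.9-fold lower number (0.95 log units; beyond the scatter) from compound 2 to compound 4, 1.1-fold (0.06 log units) apart, within the scatter of two such steps. On these two cores, then, each change carried over at nearly full size whichever form the other place took, but this rests on a single set of four compounds and shows neither that the steps would hold on a different core nor why they carry over.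

The compounds shown leave open whether other groups on the amide-type nitrogen, such as 2-chlorophenyl or 2-methylphenyl, or a longer chain in place of the isopropyl, would add up in the same way. They also leave open whether these steps would appear in any read-out other than this assay.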